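Ester to morpholine amide at the carbonyl carbon

A few compounds are considered here, and "the series" means these few. Any claim that something is new, unique, unknown or untested is made for them only; others in the source may bear on it.

Within the data shown here, compound 2 `CCOC(=O)/C=C/c1ccncc1-c1ccc2c(ccn2C)c1` gives the lowest of the two numbers so far: in an assay on a protein complex for inhibition of CDK8/Cyclin C (Homo sapiens), with a stated time of 1 h (a lower number here means a stronger inhibitor, a higher number a weaker inhibitor), compound 2 gives 144 nM. Compound 1 `O=C(/C=C/c1ccncc1-c1ccc2[nH]ccc2c1)N1CCOCC1` already carries the amide of the next target; in this assay compound 1 gives 190 nM, a gap within the scatter, so the two stand level. Compound 3 `Cn1ccc2cc(-c3cnccc3/C=C/C(=O)N3CCOCC3)ccc21` keeps the core of compound 2 and differs only in morpholin-4-yl in place of ethoxy on a carbonyl carbon. Among the measured compounds shown here, no single-site step between measured compounds covers this change; since compound 1 with the same morpholin-4-yl gives 190 nM, no step beyond the scatter is expected in this assay. For compound 3 the expected value is 170 nM, between 70 nM and 400 nM. The expected step is a 1.2-fold higher number from compound 2 to compound 3 (0.07 log units; within the scatter), within the scatter.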

Compound 3, half-maximal inhibitory concentration: 247 nM
Beside the measured number, compound 3's estimate is 1.5-fold (0.16 log units) below it; the range from low to high includes it.
By their numbers in this assay, from the lowest: compounds 2, 1 and 3 (each within the scatter of the next).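

In this assay, morpholin-4-yl in place of ethoxy on a carbonyl carbon moves the number only within the scatter (a 1.7-fold higher number from compound 2 to compound 3 (0.23 log units; within the scatter)), so this position accepts the added six-membered ring without a readable change. With morpholin-4-yl held fixed, methyl in place of hydrogen on an aromatic nitrogen also leaves the number within the scatter (a 1.3-fold higher number from compound 1 to compound 3 (0.11 log units; within the scatter)). No evidence bears on either step.

Open, as far as these compounds go, is whether a carboxylic acid or a piperazin-1-yl amide on this carbonyl carbon would give a step beyond the scatter. From the compounds shown here alone, an ethyl chain on the aromatic nitrogen also remains open.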